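The source may hold more compounds than are shown below. What is called first, only, known or untested is meant among the compounds shown, and "the series" means these compounds.

Measured compounds:
compound 1, `Nc1ncnc(Oc2ccc(NC(=O)C3(C(=O)Nc4ccc(F)cc4)CC3)cc2F)c1/C=N/OC1CCCCC1`: 4.69
compound 2, `CC(O)CO/N=C/c1c(N)ncnc1Oc1ccc(NC(=O)C2(C(=O)Nc3ccc(F)cc3)CC2)cc1F`: 2.75

In a physicochemical assay for lipophilicity, using the shake flask method (on this read-out lower numbers stand for lower lipophilicity and higher numbers for higher lipophilicity), compound 1 gives 4.69, and compound 2 gives 2.75. Among the compounds with values here, compound 2 therefore stands at the lowest of the two numbers, with compound 1 as its only neighbour, a number beyond the scatter higher. Within the data shown here, the single measured step, a number 1.94 log units lower from compound 1 to compound 2 (beyond the scatter), comes with the exchange of cyclohexyl for 2-hydroxypropyl on the oxygen.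

Compound 3, `Nc1ncnc(Oc2ccc(NC(=O)C3(C(=O)Nc4ccc(F)cc4)CC3)cc2F)c1/C=N/OC1CCCC1`, is not yet measured. It differs from compound 2 by cyclopentyl in place of 2-hydroxypropyl on an oxygen. This change runs in the opposite sense to the measured step: the 2-hydroxypropyl that brought the number down leaves again, and a ring of carbon only, akin to the cyclohexyl of compound 1, enters on the same oxygen. Because a number 1.94 log units lower from compound 1 to compound 2 (beyond the scatter) was large, a large step upward is expected in this assay, though the entering cyclopentyl is not the cyclohexyl of compound 1, so the number is expected to fall short of that of compound 1. The expected step is a number 1.45 log units higher from compound 2 to compound 3 (beyond the scatter). Compound 3 is thus estimated at 4.2, within a range from 3.7 to 4.7.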

Compound 3, partition coefficient: 4.27
For compound 3 the middle estimate is 0.07 log units below the measured one, and the stated range covers the measured number.
By their numbers in this assay, from the lowest: compound 2; then compound 3; then compound 1.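

In this assay, the oxygen whose other neighbour is the double-bonded nitrogen had so far shown a single exchange, which could not tell whether another ring of carbon only would read like cyclohexyl. Cyclopentyl in place of 2-hydroxypropyl gives a number 1.52 log units higher from compound 2 to compound 3 (beyond the scatter), so most of the gap between compound 1 and compound 2 returns with a ring that is not cyclohexyl. The two rings are still told apart on this read-out: cyclopentyl in place of cyclohexyl gives a number 0.42 log units lower from compound 1 to compound 3 (beyond the scatter), a modest step beside the large one. Nothing measured here offers an explanation for either step.

The compounds leave open whether it is the hydroxyl of 2-hydroxypropyl or the absence of a ring that goes with the low number of compound 2, as that exchange alters both at once. They also do not tell how a smaller ring such as cyclobutyl, an open carbon chain such as isopropyl, or a chain ending in an amine or a carboxylic acid would read on the same oxygen in this assay.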